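A few compounds are considered here, and "the series" means these few. Any claim that something is new, unique, unknown or untested is made for them only; others in the source may bear on it.

Measured in a functional assay on HeLa cells (Homo sapiens) for inhibition, read by sulforhodamine B assay; on this read-out higher numbers stand for weaker inhibition and lower numbers for stronger inhibition:
- Compound 1 `Cc1ccc(NC2=CC(=O)c3c(nc4n3[C@H]3OC[C@@H](O)[C@H]3OC4)C2=O)cc1C`: 4320 nM
- Compound 2 `CCc1ccc(NC2=CC(=O)c3nc4n(c3C2=O)[C@H]2OC[C@@H](O)[C@H]2OC4)cc1`: 3990 nM
- Compound 3 `O=C1C(N2CCCCC2)=CC(=O)c2c1nc1n2[C@H]2OC[C@@H](O)[C@H]2OC1`: > 16000 nM, which is a limit of the assay and not a number

Compound 2 at 3990 nM and compound 1 at 4320 nM lie within the scatter of each other. Compound 4 `CCOc1ccccc1NC1=CC(=O)c2nc3n(c2C1=O)[C@H]1OC[C@@H](O)[C@H]1OC3` keeps the core of compound 2, with 2-ethoxyphenyl in place of 4-ethylphenyl on an amine nitrogen.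

For the measured compounds named here, only one measured step bears on this change: an at least 3.7-fold higher number from compound 1 to compound 3 (0.56 log units; beyond the scatter). There, piperidin-1-yl takes the place of (3,4-dimethylphenyl)amino, so the aromatic ring on that nitrogen is lost. Compound 4 keeps such a ring, so no comparable shift is expected in this assay. The expected step, a 1.1-fold higher number from compound 2 to compound 4 (0.05 log units; within the scatter), is not expected to go beyond the scatter. For compound 4 the estimated value is 4500 nM, with an expected range of 1800 nM to 11000 nM.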

Compound 4, half-maximal inhibitory concentration: 6040 nM
Estimate against measurement, compound 4: 1.3-fold (0.13 log units) below; the measured number falls inside the stated range.
By their numbers in this assay, from the lowest: compounds 2, 1 and 4 (each within the scatter of the next). At a limit, above all of these: compound 3.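

In this assay, 2-ethoxyphenyl in place of 4-ethylphenyl on the amine nitrogen gives a 1.5-fold higher number from compound 2 to compound 4 (0.18 log units; within the scatter). The aromatic ring on this nitrogen can therefore carry an oxygen-containing group, with a hydrogen-bond acceptor, and the number stays within the scatter, whereas the rings of compound 1 and compound 2 carry only carbon groups. No available evidence bears on this small step.

Going by these compounds, whether a carboxylic acid or an amine on that ring would also leave the number unchanged remains open. The same applies to a longer chain such as butoxy.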